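The source may report more compounds than this note shows. Statements on the series, on what has been measured and on what is new or still open speak of the compounds shown alone.

Compound 1 `COc1ccc(S(=O)(=O)NCCN2CCC(CCC(=O)c3cc(Cl)c(N)cc3OC)CC2)cc1Cl` is the weaker of the two compounds measured in an assay on HEK293 cells for displacement of a labelled ligand from 5-hydroxytryptamine receptor 6 (Homo sapiens), with a stated time of 60 min, tested at 0.01 uM, in the presence of a further agent that is not named here (on this read-out higher numbers stand for a stronger effect at the one concentration tested and lower numbers for a weaker effect), where compound 1 gives 20%. Among the compounds with values here, its one neighbour is compound 2 `COc1cc(N)c(Cl)cc1C(=O)CCC1CCN(CCNS(=O)(=O)c2cc(Br)c(N)c(Br)c2)CC1`, which in this assay gives 52%; the step of a number 32 percentage points higher from compound 1 to compound 2 (beyond the scatter) shows that exchanging the aryl group on the sulfonyl sulfur can move the read-out well beyond the scatter. Compound 3 `COc1ccc(S(=O)(=O)NCCN2CCC(CCC(=O)c3cc(Cl)c(N)cc3OC)CC2)c(OC)c1` has not yet been measured. It differs from compound 1 at the same place, (2,4-dimethoxyphenyl in place of 3-chloro-4-methoxyphenyl on a sulfonyl sulfur), but the group that enters is not the one that carried the gain in compound 2, so that step offers only the lesson that this position is sensitive, not a direction. With no measured change resembling this one, the expectation for compound 3 is a read-out close to that of compound 1, with wide uncertainty, and compound 3 is estimated at 22% (range 5% to 45%), which means an expected step of a number 2 percentage points higher from compound 1 to compound 3 (within the scatter).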

Compound 3, a percentage reported as inhibition, at one concentration (the size of the read-out at that concentration, not a potency): "not active" (no number reported)
For compound 3 the study gives words and no number; the estimate stays without a comparison.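

Within the data shown here, compound 3 is reported in this assay only in words, as "not active", so no step from compound 1 to compound 3 can be read. Nothing further given here bears on this result. The compounds shown leave open how compound 3 compares numerically with compound 1.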